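A hydroxyphenyl exchange on compound 2

The compounds below may be only part of what the source reports. "The series", "measured", "known", "first", "only" and "open" are said of these compounds alone.

Compound 1 (`O=C(/C=C/c1ccc(O)cc1)NC1CCN(Cc2ccccc2)CC1`): 980000 nM
Compound 2 (`COc1ccc(/C=C/C(=O)NCCC2CCN(Cc3ccccc3)CC2)cc1O`): 764000 nM

In a physicochemical assay, read by spectrophotometry, with a stated time of 30 min (a higher number here means a weaker inhibitor, a lower number a stronger inhibitor), the two measured compounds lie within the scatter of each other: compound 2 gives 764000 nM and compound 1 gives 980000 nM as its value, so neither can be ranked over the other. Compound 3 (`O=C(/C=C/c1ccccc1O)NCCC1CCN(Cc2ccccc2)CC1`) has not yet been measured. It differs from compound 2 in one place, with 2-hydroxyphenyl in place of 3-hydroxy-4-methoxyphenyl on a double-bonded chain carbon bound to a double-bonded chain carbon.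

For the measured compounds named here, no measured pair of compounds differs in one place only, so the data give no direct size for this exchange. Going by the values given here, the only guide is how close the two known numbers are, with compound 1 at 980000 nM and compound 2 at 764000 nM in the same range. In this assay no step beyond the scatter is therefore expected, in either direction. Estimated as a step, this is a 1.0-fold higher number from compound 2 to compound 3 (0.02 log units; within the scatter) as the expected change. The expected value for compound 3 is 800000 nM with an estimated range from 300000 nM to 2000000 nM for the measurement.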

Compound 3, half-maximal inhibitory concentration: 977000 nM
Beside the measured number, compound 3's estimate is 1.2-fold (0.09 log units) below it; the range from low to high includes it.
By their numbers in this assay, from the lowest: compounds 2, 3 and 1 (each within the scatter of the next).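

In this assay, for the compounds shown here, the exchange of 3-hydroxy-4-methoxyphenyl for 2-hydroxyphenyl on a double-bonded chain carbon bound to a double-bonded chain carbon gives a 1.3-fold higher number from compound 2 to compound 3 (0.11 log units; within the scatter), which supplies the first direct reading of a change in one place and leaves compound 2 and compound 3 unranked. The exchange takes this group from 9 heavy atoms to 7 heavy atoms and from 2 hydrogen-bond acceptors to 1 hydrogen-bond acceptor, while the single hydrogen-bond donor stays, and for this pair that difference produces no step beyond the scatter. No independent measurement is available to explain the size of this step.

Going by these compounds alone, only one exchange at this place can be read, so it remains open whether any other group here would move the number beyond the scatter, for example a phenyl ring carrying an amine, a carboxylic acid or a nitrile in place of the hydroxy and methoxy groups. Going by these compounds, compound 1 differs from compound 2 and compound 3 in more than one place, so the effect of the chain on the far side of the amide also remains open, as does that of a longer chain there.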